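The source may hold more compounds than are shown below. What is called first, only, known or untested is meant among the compounds shown, and "the series" means these compounds.

Measured so far in a functional assay on A-431 cells (Homo sapiens) for cytotoxicity; a lower number here means that less compound is needed, a higher number that more compound is needed for the effect:
- compound 1 `COC1=C(C)C(=O)/C(=C(O)/C=C/c2ccc(C)cc2)C(=O)C1(C)C`: 5.1 ug/mL
- compound 2 `COC1=C(C)C(=O)/C(=C(O)/C=C/c2ccccc2C)C(=O)C1(C)C`: 5.2 ug/mL

Compound 2 has a single neighbour on these numbers and does not separate from it. Compound 3 `COC1=C(C)C(=O)/C(=C(O)/C=C/c2cc(C)cc(C)c2)C(=O)C1(C)C` carries 3,5-dimethylphenyl in place of 2-methylphenyl, on a double-bonded chain carbon bound to a double-bonded chain carbon: 3,5-dimethylphenyl in place of 2-methylphenyl on a double-bonded chain carbon bound to a double-bonded chain carbon. Going by the values given here, one measured step bears on this, the exchange of 4-methylphenyl for 2-methylphenyl at that place, a 1.0-fold higher number from compound 1 to compound 2 (0.01 log units; within the scatter), which lies within the scatter. Among the compounds with values here, it is a single step, and the added methyl of the new group has no measured precedent. The expected step is a 1.1-fold lower number from compound 2 to compound 3 (0.03 log units; within the scatter), so no change beyond the scatter is expected in this assay. The estimate for compound 3 is 4.8 ug/mL, with an expected range of 2.5 ug/mL to 9 ug/mL.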

Compound 3, concentration for half-maximal effect: 4 ug/mL
Compound 3: the middle estimate sits 1.2-fold (0.08 log units) above what was measured; the measured number falls inside the stated range.
By their numbers in this assay, from the lowest: compounds 3, 1 and 2 (each within the scatter of the next).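

In this assay, 3,5-dimethylphenyl on a double-bonded chain carbon bound to a double-bonded chain carbon does not separate from either single-methyl group: a 1.3-fold lower number from compound 2 to compound 3 (0.11 log units; within the scatter) and a 1.3-fold lower number from compound 1 to compound 3 (0.11 log units; within the scatter). Across compounds 1, 2 and 3, a second methyl on the phenyl therefore gives no step beyond the scatter. No available evidence bears on this result.

The compounds shown carry only methyl groups on the phenyl. They leave open whether an amine, a carboxylic acid or a longer chain there would separate from these numbers.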